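The compounds below may be only part of what the source reports. "The series", "measured", "known", "first", "only" and "open" are said of these compounds alone.

Three compounds have been measured in a functional assay on A-375 cells (Homo sapiens) for cytotoxicity, read by MTT assay, with a stated time of 48 h; on this read-out higher numbers stand for weaker inhibition and lower numbers for stronger inhibition:
compound 1 `CC1(C)S[C@@H]2/C(=C\C(=O)c3cc(F)cc(F)c3)C(=O)N2[C@H]1C(=O)OC(c1ccccc1)c1ccccc1` gives 19100 nM;
compound 2 `CC1(C)S[C@@H]2/C(=C\C(=O)c3ccccc3)C(=O)N2[C@H]1C(=O)OC(c1ccccc1)c1ccccc1` gives 22800 nM;
compound 3 `CCOC(=O)/C=C1/C(=O)N2[C@@H]1SC(C)(C)[C@@H]2C(=O)OC(c1ccccc1)c1ccccc1` gives 7000 nM.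

Compound 3 has the lowest number of the three, and its distance from each of the other two lies beyond the scatter. Compound 4 `CC1(C)S[C@@H]2/C(=C\C(=O)c3ccc4ccccc4c3)C(=O)N2[C@H]1C(=O)OC(c1ccccc1)c1ccccc1` differs from compound 3 in one place: naphthalen-2-yl in place of ethoxy on a carbonyl carbon. Among the measured compounds shown here, two measured steps bear on this. Compound 1 and compound 2 carry a 3,5-difluorophenyl or a phenyl group on that carbonyl carbon, and the step of a 2.7-fold lower number from compound 1 to compound 3 (0.44 log units; beyond the scatter) together with the step of a 3.3-fold lower number from compound 2 to compound 3 (0.51 log units; beyond the scatter) point the same way: the ethoxy gives a lower number than either aryl group. Going the other way, to a naphthalen-2-yl group, compound 4 is expected to show a higher number, roughly a 2.6-fold higher number from compound 3 to compound 4 (0.41 log units; beyond the scatter). The estimate for compound 4 is 18000 nM, with a range from 8000 nM to 40000 nM.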

Compound 4, half-maximal inhibitory concentration: 36500 nM
Compound 4: the middle estimate sits 2.0-fold (0.31 log units) below what was measured; the measured number falls inside the stated range.
By their numbers in this assay, from the lowest: compound 3; then compounds 1, 2 and 4 (each within the scatter of the next).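

Naphthalen-2-yl in place of ethoxy gives a 5.2-fold higher number from compound 3 to compound 4 (0.72 log units; beyond the scatter) in this assay, so ethoxy's lower number also holds against an aryl group with two rings. Against the single-ring groups, a 1.6-fold higher number from compound 2 to compound 4 (0.20 log units; within the scatter) and a 1.9-fold higher number from compound 1 to compound 4 (0.28 log units; within the scatter) both stay within the scatter, so compounds 1, 2 and 4 cannot be told apart and the second ring shows no clear effect here. No measured evidence bears on this result.

As far as these compounds go, whether the lower number is special to ethoxy stays open. A carboxylic acid, an amine-derived amide or a longer chain such as butoxy on this carbonyl carbon could show how far it extends.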